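Two inactive imidazoles and a next candidate

The compounds below may be only part of what the source reports. "The series", "measured", "known", "first", "only" and "open" are said of these compounds alone.

Compound 1 `COc1ccc(-c2nc(-c3ccccc3)c(-c3ccc4c(c3)NC(=O)CO4)[nH]2)cc1`: 108%
Compound 2 `O=C1COc2ccc(-c3nn(-c4ccc(Br)cc4)cc3-c3ccccc3)cc2N1`: 108%

In a functional assay on MV4-11 cells (Homo sapiens) for cytotoxicity, read by colorimetric assay and MTT assay, with a stated time of 3 days, tested at 1 uM (a higher number here means a weaker effect of the compound at the concentration tested, a lower number a stronger effect), compound 1 gives 108%, and compound 2 gives 108%, so the two stand level within the scatter and neither shows an effect at this concentration. Compound 3 `O=C1COc2ccc(-c3[nH]c(-c4c[nH]c5ncccc45)nc3-c3ccccc3)cc2N1` carries one change from compound 1: a group of 9 heavy atoms (7 carbon, 2 nitrogen; one five-membered aromatic ring with 1 hetero atom, one six-membered aromatic ring with 1 hetero atom) in place of a group of 8 heavy atoms (7 carbon, 1 oxygen; one six-membered aromatic ring of carbon only), on an aromatic carbon. Among the measured compounds shown here, no measured pair shows this kind of change, so its effect cannot be read from the data. The expected step of a number 13 percentage points lower from compound 1 to compound 3 (beyond the scatter) is a modest drop that may not exceed the scatter. Compound 3 is therefore expected to give 95%, with a range from 55% to 112%.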

Compound 3, a percentage reported as activity, at one concentration (the size of the read-out at that concentration, not a potency): 111%
For compound 3 the middle estimate is 16 percentage points below the measured one; low and high end bracket the measured number.
By their numbers in this assay, from the lowest: compounds 1, 2 and 3 (each within the scatter of the next).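

Putting the two-ring group in place of 4-methoxyphenyl, on the aromatic carbon between two ring nitrogen atoms, gives a number 3 percentage points higher from compound 1 to compound 3 (within the scatter) in this assay and so leaves the read-out where it was. Compound 3, like compound 1, shows no effect at the concentration tested, so this position tolerates the exchange without any gain in effect. Nothing at hand explains this result.

On these data alone, what stays open is whether a different kind of group at this carbon, such as an aliphatic amine or a carboxylic acid, would lower the number at all.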